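A few compounds are considered here, and "the series" means these few. Any claim that something is new, unique, unknown or untested is made for them only; others in the source may bear on it.

Measured so far in a functional assay on HCC827 cells (Homo sapiens) for inhibition, read by fluorescence, with a stated time of 72 h; a lower number here means a stronger inhibitor of growth, a higher number a weaker inhibitor of growth:
- compound 1 `COc1ccc(Nc2nc(N[C@H]3CC[C@H](N)CC3)nc3c2ncn3CCC(C)C)c(OC)c1`: 32900 nM
- compound 2 `CC(C)CCn1cnc2c(NCc3cccc(Cl)c3)nc(N[C@H]3CC[C@H](N)CC3)nc21`: 16700 nM
- compound 3 `CCCCCCn1cnc2c(Nc3cccc(Cl)c3)nc(N[C@H]3CC[C@H](N)CC3)nc21`: 10200 nM

Compound 3 stands within the scatter of compound 2 and beyond the scatter under compound 1. Compound 4 `CC(C)CCn1cnc2c(Nc3cccc(Cl)c3)nc(N[C@H]3CC[C@H](N)CC3)nc21` differs from compound 3 only in the chain: isopropyl in place of butyl on a saturated chain carbon, two bonds along the chain from an aromatic nitrogen. Going by the values given here, no measured step covers this change. Among the compounds with values here, the one measured step, a 2.0-fold lower number from compound 1 to compound 2 (0.29 log units; within the scatter), lies on a nitrogen on an aromatic ring, elsewhere in the structure, and stays within the scatter. Compound 2 already carries the isopentyl chain and gives 16700 nM, so no shift beyond the scatter is expected in this assay. The expected step is a 1.2-fold higher number from compound 3 to compound 4 (0.07 log units; within the scatter). The estimate for compound 4 is 12000 nM, with a range of 5500 nM to 26000 nM.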

Compound 4, concentration for 50% growth inhibition: 10300 nM
Compound 4: the middle estimate sits 1.2-fold (0.07 log units) above what was measured; the range from low to high includes it.
By their numbers in this assay, from the lowest: compounds 3, 4, 2 and 1 (each within the scatter of the next, the first and the last beyond it).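

In this assay, the chain position tolerates isopropyl in place of butyl, the change from hexyl to isopentyl, with a 1.0-fold higher number from compound 3 to compound 4 (0.00 log units; within the scatter) as the step. On the isopentyl chain, a 1.6-fold lower number from compound 2 to compound 4 (0.21 log units; within the scatter) does not separate 3-chlorophenyl from 3-chlorobenzyl, whereas a 3.2-fold lower number from compound 1 to compound 4 (0.50 log units; beyond the scatter) puts 3-chlorophenyl in place of 2,4-dimethoxyphenyl as a modest gain beyond the scatter. No evidence on the origin of these steps is available.

Still open, from the compounds shown here alone, is whether a chain ending in an amine or a carboxylic acid would move the number in this assay at all. Going by these compounds, the effect of a fluoro or methoxy group in place of chloro on the phenyl ring also remains open.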